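Swapping a Pyridine Substituent: Effect on Vero Cell Tolerance

The compounds below may be only part of what the source reports. "The series", "measured", "known", "first", "only" and "open" are said of these compounds alone.

Compound 1 `Fc1ccc(-c2nn3c(NC4CCCC4)cccc3c2-c2ccnnc2)cc1`: "not determined" (no result reported)
Compound 2 `NNc1cc(-c2c(-c3ccc(F)cc3)nn3c(NC4CCCC4)cccc23)ccn1`: 40000 nM

Two compounds share a core that carries a cyclopentylamino group and a 4-fluorophenyl group. In an ADME assay on Vero cells (Chlorocebus sabaeus) for cytotoxicity (a higher number here means that more compound is tolerated, a lower number that less compound is tolerated), compound 2 gives 40000 nM, while compound 1 gives "not determined" (no result reported). Among the measured compounds shown here, compound 2 therefore stands as the only number available, with nothing to rank it against.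

Compound 3 `Fc1ccc(-c2nn3c(NC4CCCC4)cccc3c2-c2cccnc2)cc1` differs from compound 2 in one place: pyridin-3-yl in place of 2-(aminoamino)pyridin-4-yl on an aromatic carbon. For the measured compounds named here, no step between two measured compounds is on hand, so the size of this change can only be guessed. The expectation is that the step from compound 2 to compound 3 in this assay, a 1.3-fold lower number from compound 2 to compound 3 (0.12 log units; within the scatter), is small and lies within the usual scatter, with no clear direction. For compound 3 the estimate is 30000 nM, in a range from 10000 nM to 100000 nM.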

Compound 3, half-maximal cytotoxic concentration: > 40000 nM
Compound 3: no number, only a limit; the forecaster's own chance of this, stated with the estimate: 30%; middle value at least 1.3-fold (0.12 log units) away from the limit.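

Replacing 2-(aminoamino)pyridin-4-yl with pyridin-3-yl on this aromatic carbon, next to the ring atom that bears the 4-fluorophenyl group, does not lower the tolerated concentration in this assay: the change gives a number no lower from compound 2 to compound 3 (the limit leaves the size open). Compound 3 has only a limit, > 40000 nM, and not an exact number. The size of the step cannot be read because of this limit: the limit of > 40000 nM in this assay, at which 1 of the 3 values shown sits.

As far as these compounds go, how far compound 3 really lies from compound 2 in this assay therefore stays open. The compounds shown also leave open how the pyridin-3-yl group would behave at this position if it carried a simple amine or a methoxy group, which would help separate the effect of the ring from that of its substituent.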